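The source may hold more compounds than are shown below. What is called first, only, known or untested is meant among the compounds shown, and "the series" means these compounds.

Three compounds built on the core of compound 1 `CC(C)(C)NC(=O)NCCS(=O)(=O)NC(=O)c1ccc(Nc2nc(NC3(c4ccc(Cl)cc4)CC3)nc(OCC(F)(F)F)n2)cc1` differ only in the group attached to a carbonyl carbon. In a physicochemical assay for permeability, using PAMPA, at pH 7.4 (on this read-out lower numbers stand for lower permeability and higher numbers for higher permeability), compound 1 gives 49 nm/s. Compound 2 `CC(=O)NCCS(=O)(=O)NC(=O)c1ccc(Nc2nc(NC3(c4ccc(Cl)cc4)CC3)nc(OCC(F)(F)F)n2)cc1` gives 7 nm/s, and compound 3 `O=C(NS(=O)(=O)CCNC(=O)C1CC1)c1ccc(Nc2nc(NC3(c4ccc(Cl)cc4)CC3)nc(OCC(F)(F)F)n2)cc1` gives 1 nm/s. Compound 3 thus stands lowest of the three numbers: its nearest neighbour is seen in a 7.0-fold lower number from compound 2 to compound 3 (0.85 log units; beyond the scatter), and its furthest in a 49-fold lower number from compound 1 to compound 3 (1.69 log units; beyond the scatter). The change to compound 4 `CC(C)NC(=O)NCCS(=O)(=O)NC(=O)c1ccc(Nc2nc(NC3(c4ccc(Cl)cc4)CC3)nc(OCC(F)(F)F)n2)cc1` is isopropylamino in place of cyclopropyl on a carbonyl carbon. The step that bears most directly on it is a 49-fold lower number from compound 1 to compound 3 (1.69 log units; beyond the scatter), which runs the other way and exchanges a related group; a 7.0-fold lower number from compound 1 to compound 2 (0.85 log units; beyond the scatter) and a 7.0-fold lower number from compound 2 to compound 3 (0.85 log units; beyond the scatter) point the same way, with cyclopropyl giving the lowest number in each case. A clear rise is therefore expected, though not the full return to the number of compound 1, since isopropylamino rather than (tert-butyl)amino enters. Compound 4 is expected to show a 20-fold higher number from compound 3 to compound 4 (1.30 log units; beyond the scatter), landing at an estimated 20 nm/s, within a range of 5 nm/s to 60 nm/s.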

Compound 4, apparent permeability: 45 nm/s
Compound 4: the middle estimate sits 2.3-fold (0.35 log units) below what was measured; the measured number falls inside the stated range.
By their numbers in this assay, from the lowest: compound 3; then compound 2; then compounds 4 and 1 (each within the scatter of the next).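

In this assay the isopropylamino group on this carbonyl carbon sits far from the two carbon-linked groups, with a 45-fold higher number from compound 3 to compound 4 (1.65 log units; beyond the scatter) against cyclopropyl and a 6.4-fold higher number from compound 2 to compound 4 (0.81 log units; beyond the scatter) against methyl as the steps from those groups. Set against the (tert-butyl)amino group, the change reads a 1.1-fold lower number from compound 1 to compound 4 (0.04 log units; within the scatter) and stays within the scatter, so in these four compounds the two groups with a nitrogen on the carbonyl carbon stand together, above methyl and cyclopropyl, and no compound goes against this. Nothing measured here accounts for this pattern.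

On these data alone, whether it extends to a plain amino group or a methylamino group on this carbonyl carbon stays open. So does whether a tert-butyl group, with carbon in place of that nitrogen, would stand with methyl and cyclopropyl.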